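A few compounds are considered here, and "the series" means these few. Any claim that something is new, unique, unknown or untested is made for them only; others in the source may bear on it.

Measured compounds in a functional assay on HCT-116 cells (Homo sapiens) for antiproliferative activity, read by MTT assay, with a stated time of 72 h; on this read-out higher numbers stand for weaker inhibition and lower numbers for stronger inhibition:
- compound 1, `O=C1O/C(=C\Cn2cc(-c3cc(F)cc(F)c3)nn2)C(OCc2ccccc2)=C1OCc1ccccc1`, gives > 100000 nM.
- compound 2, `O=C1O[C@H]([C@@H](O)Cn2cc(CNS(=O)(=O)c3ccc(F)cc3)nn2)C(OCc2ccccc2)=C1OCc1ccccc1`, gives 22900 nM.
- compound 3, `C[Si](C)(C)c1cn(C[C@H](O)[C@H]2OC(=O)C(OCc3ccccc3)=C2OCc2ccccc2)nn1`, gives 31800 nM.

The value given by compound 1 is a limit of this assay, not a number, as stated in the limit of > 100000 nM in this assay, at which 1 of the 3 values shown sits. Among the two numbers that were actually read, compound 3 stands highest; its nearest neighbour is compound 2, and the gap between them is within the scatter of the method.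

Compound 4, `Cc1ccc(-c2cn(C[C@H](O)[C@H]3OC(=O)C(OCc4ccccc4)=C3OCc3ccccc3)nn2)cc1`, differs from compound 3 at a single place on the five-membered aromatic ring with three nitrogens:

a group of 7 heavy atoms (7 carbon; one six-membered aromatic ring of carbon only) in place of a group of 4 heavy atoms (3 carbon, 1 silicon; no ring), on an aromatic carbon

Among the measured compounds shown here, only one measured step touches this position. From compound 2 to compound 3 it was a 1.4-fold higher number from compound 2 to compound 3 (0.14 log units; within the scatter), a change that exchanged a much larger group for the small silicon-bearing one without moving the number beyond the scatter. For the measured compounds named here, compound 1 carries a six-membered aromatic ring on the same kind of position, but its core differs in other places too, so its limit gives no clean step. On this evidence the substituent on this ring appears to matter little, and the step from compound 3 to compound 4 is expected to be a 1.2-fold lower number from compound 3 to compound 4 (0.09 log units; within the scatter), that is, no change beyond the scatter. Compound 4 is therefore estimated to give 26000 nM in this assay, with a range from 8000 nM to 80000 nM.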

Compound 4, half-maximal inhibitory concentration: > 100000 nM
Compound 4 ended at the assay's limit; the forecaster's own chance of this, stated with the estimate: 15%; at least 3.8-fold (0.58 log units) between middle value and limit.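

In this assay compound 4 stands at a limit and not at a number: the limit of > 100000 nM in this assay, at which 2 of the 4 values shown sit.

Even so, the steps can be read as lower bounds, with an at least 3.1-fold higher number from compound 3 to compound 4 (0.49 log units; beyond the scatter) and an at least 4.3-fold higher number from compound 2 to compound 4 (0.64 log units; beyond the scatter), both beyond the scatter, whereas the earlier step at this aromatic carbon, a 1.4-fold higher number from compound 2 to compound 3 (0.14 log units; within the scatter), stayed within it. The position is therefore not indifferent to what it carries, and the count of heavy atoms does not order the three groups: 4-methylphenyl has fewer heavy atoms than the (((4-fluorophenyl)sulfonyl)amino)methyl group of compound 2 and more than the silicon-bearing group of compound 3, yet it alone moves the result beyond the scatter.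

As far as these compounds go, this rests on a single entering group, so it remains open whether the aromatic ring or its methyl accounts for the change. From the compounds shown here alone, it also remains open whether an unsubstituted phenyl, a pyridine ring, a longer alkyl chain or a chain ending in an amine on this carbon would give a number within the range of the assay.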